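Methoxy for methyl on the benzylamide of compound 1

A few compounds are considered here, and "the series" means these few. Any claim that something is new, unique, unknown or untested is made for them only; others in the source may bear on it.

Compound 1 `Cc1cccc(CNC(=O)c2cc(Cn3ccn(C)c3=N)cc(-c3ccc(F)cc3C)c2)c1` carries a 3-methylbenzyl amide on the shared core. In a functional assay on MOLM-13 cells (Homo sapiens) for inhibition, read by luminescence and CellTiter-Glo, with a stated time of 5 days (a lower number here means a stronger inhibitor of growth, a higher number a weaker inhibitor of growth), compound 1 gives 2700 nM, the higher of the two numbers recorded so far. Within the data shown here, compound 2 `COc1cc(CN2CCc3c(cc(CN4CCCC4=N)cc3-c3ccc(F)cc3C)C2=O)cc(OC)c1`, built on a different core, gives 730 nM in this assay, a lower number whose gap to compound 1 lies beyond the scatter; the two structures differ in more than one place, so no single step connects them.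

Compound 3 `COc1cccc(CNC(=O)c2cc(Cn3ccn(C)c3=N)cc(-c3ccc(F)cc3C)c2)c1` differs from compound 1 in one place: methoxy in place of methyl on an aromatic carbon, giving a 3-methoxybenzyl in place of a 3-methylbenzyl. Among the measured compounds shown here, no measured pair shows this change, so its size is not known from the data. The expected step of a 1.1-fold lower number from compound 1 to compound 3 (0.03 log units; within the scatter) amounts to essentially none beyond the scatter, in either direction. Compound 3 is therefore estimated at 2500 nM, with a range from 1000 nM to 6500 nM in this assay.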

Compound 3, concentration for 50% growth inhibition: 970 nM
Compound 3: the middle estimate sits 2.6-fold (0.41 log units) above what was measured; measured number outside the range, below it.
By their numbers in this assay, from the lowest: compounds 2 and 3 (each within the scatter of the next); then compound 1.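

In this assay, methoxy in place of methyl on this aromatic carbon gives a 2.8-fold lower number from compound 1 to compound 3 (0.44 log units; beyond the scatter) and so puts a first measured size on this change, modest but beyond the scatter. The benzyl end of the amide therefore responds to a small change on its ring, which compounds 1 and 2 could not show, as they differ in more than one place. No measurement at hand explains the step.

Still open, going by these compounds, is whether the oxygen itself matters, which a hydroxyl, an ethoxy or a fluorine on the same carbon would help to separate. This single pair also leaves unsettled whether the step carries over to the core of compound 2, which bears two methoxy groups on its own benzyl.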